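The source may hold more compounds than are shown below. What is called first, only, known or untested is meant among the compounds shown, and "the series" means these compounds.

Measured compounds:
Compound 1, `COc1cc(/C=N/Nc2nc(-c3ccccc3)cs2)c(Br)c(Br)c1OC`: 20100 nM
Compound 2, `COc1cc(/C=N/Nc2nc(-c3ccccc3)cs2)cc(Br)c1OC`: 74100 nM
Compound 3, `Fc1ccc(/C=N/Nc2nc(-c3ccc(Br)cc3)cs2)cc1F`: > 100000 nM

Three compounds were tested in a functional assay on U-87MG ATCC cells for inhibition, with U-87 MG (Homo sapiens) as the target, read by MTT assay, with a stated time of 48 h; on this read-out higher numbers stand for weaker inhibition and lower numbers for stronger inhibition. Compound 1 gives 20100 nM, the lowest of the two numbers reported. Compound 2 gives 74100 nM, and the step of a 3.7-fold higher number from compound 1 to compound 2 (0.57 log units; beyond the scatter) arises from hydrogen in place of bromo on an aromatic carbon. For compound 3 only a limit of the assay is reported, > 100000 nM; the fact that one of the three values sits at this limit is recorded as the limit of > 100000 nM in this assay, at which 1 of the 3 values shown sits.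

The unmeasured compound 4, `COc1cc(/C=N/Nc2nc(-c3ccc(C(F)(F)F)cc3)cs2)c(Br)c(Br)c1OC`, is compound 1 with one change: trifluoromethyl in place of hydrogen on an aromatic carbon. For the measured compounds named here, none of the measured steps involves this change; the only measured step concerns a bromo substituent elsewhere on the shared core, and compound 3, which carries a different group on the same aromatic ring, also differs from compound 1 in other places, so it offers no single-step comparison. With no direct evidence, the expectation is a step of a 1.2-fold higher number from compound 1 to compound 4 (0.09 log units; within the scatter) that stays within the usual scatter, with no clear direction. Compound 4 is therefore estimated at 25000 nM in this assay , with a range from 8000 nM to 80000 nM.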

Compound 4, half-maximal inhibitory concentration: > 100000 nM
Compound 4 ended at the assay's limit (the forecaster's own chance of this, stated with the estimate: 15%); at least 4.0-fold (0.60 log units) between middle value and limit.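

In this assay, the change from phenyl to 4-(trifluoromethyl)phenyl gives an at least 4.9-fold higher number from compound 1 to compound 4 (0.69 log units; beyond the scatter), which shows that the read-out responds to this ring as well as to the bromo substituent behind the earlier step. The value of compound 4, > 100000 nM, is a limit of the assay, so the step marks only a minimum size and its full extent cannot be read. Such a limit is not rare among the compounds shown: the limit of > 100000 nM in this assay, at which 2 of the 4 values shown sit.

What the compounds leave open is whether any group at this place on the core of compound 1 would give a lower number than hydrogen does, since hydrogen and trifluoromethyl are the only two shown there on that core. From the compounds shown here alone, a methoxy group, an amine or a carboxylic acid in the same place could answer that, and it also remains open whether trifluoromethyl would have a similar effect on the core of compound 2, which has hydrogen in place of one bromo.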